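Swapping a fluorophenyl for a naphthyl on a shared core

The source may hold more compounds than are shown below. What is called first, only, known or untested is meant among the compounds shown, and "the series" means these compounds.

Within the data shown here, compound 2 `Fc1ccc(Cn2cc(CSc3nnc(-c4ccccc4)c(-c4ccccc4)n3)nn2)cc1` is the only compound with a number in a functional assay on MGC-803 cells (Homo sapiens) for antiproliferative activity, read by MTT assay, with a stated time of 48 h; on this read-out lower numbers stand for stronger inhibition and higher numbers for weaker inhibition; compound 2 gives 7590 nM. Compound 1 `Brc1ccc(Cn2cc(CSc3nnc(-c4ccccc4)c(-c4ccccc4)n3)nn2)cc1` reaches only the limit > 100000 nM, which is a limit and not a number (the limit of > 100000 nM in this assay, at which 1 of the 2 values shown sits). Among the measured compounds shown here, the one measured step, an at least 13-fold lower number from compound 1 to compound 2 (1.11 log units; beyond the scatter), concerns a halogen swap and bears only indirectly on compound 3 `c1ccc(-c2nnc(SCc3cn(Cc4ccc5ccccc5c4)nn3)nc2-c2ccccc2)cc1`, where the change is naphthalen-2-yl in place of 4-fluorophenyl on a saturated chain carbon bound to an aromatic nitrogen. For the measured compounds named here, no measured step covers this change, so its direction is open. From compound 2 to compound 3 the expected step is a 1.6-fold higher number from compound 2 to compound 3 (0.20 log units; within the scatter), giving for compound 3 an estimate of 12000 nM, within 2000 nM to 100000 nM.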

Compound 3, half-maximal inhibitory concentration: > 100000 nM
Compound 3 gave a limit, no number; the forecaster's own chance of this, stated with the estimate: 25%; middle value at least 8.3-fold (0.92 log units) away from the limit.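

Placing naphthalen-2-yl instead of 4-fluorophenyl on this saturated chain carbon bound to an aromatic nitrogen weakens the result in this assay, with an at least 13-fold higher number from compound 2 to compound 3 (1.11 log units; beyond the scatter). The position therefore responds to a change of the whole ring group as well as to a halogen swap, and among the groups shown only 4-fluorophenyl gives a number. Both ends of the remaining step are limits, so the step from compound 1 to compound 3 cannot be read: the limit of > 100000 nM in this assay, at which 2 of the 3 values shown sit.

From the compounds shown here alone, whether a plain phenyl or a pyridine ring here would give a number as low as that of compound 2, or a lower one, stays open.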